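Shortening the Chain of a 4-Pentylphenyl Group

The source may hold more compounds than are shown below. What is called first, only, known or untested is meant among the compounds shown, and "the series" means these compounds.

Compound 1 `O=C1O/C(=C\Cn2cc(-c3ccc(Br)cc3)nn2)C(OCc2ccccc2)=C1OCc1ccccc1` in a functional assay on CFPAC-1 cells (Homo sapiens) for antiproliferative activity, read by MTT assay, with a stated time of 72 h (on this read-out higher numbers stand for weaker inhibition and lower numbers for stronger inhibition), gives a limit of the assay, > 100000 nM.
Compound 2 `CCCCCc1ccc(-c2cn(C/C=C3\OC(=O)C(OCc4ccccc4)=C3OCc3ccccc3)nn2)cc1` in this assay gives a limit of the assay, > 100000 nM.
Compound 3 `CCCCCc1ccc(-c2cn(C[C@H](O)[C@H]3OC(=O)C(OCc4ccccc4)=C3OCc3ccccc3)nn2)cc1` in this assay gives 9890 nM.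

Compound 3 is the only one of the three with a number in this assay; the other two values are limits, as recorded in the limit of > 100000 nM in this assay, at which 2 of the 3 values shown sit, so no ordering among the three can be read from them.

The compound not yet measured is compound 4 `Cc1ccc(-c2cn(C[C@H](O)[C@H]3OC(=O)C(OCc4ccccc4)=C3OCc3ccccc3)nn2)cc1`. It differs from compound 3 by hydrogen in place of butyl on a saturated chain carbon bound to an aromatic carbon. For the measured compounds named here, the only measured step that touches the same part of the molecule is a step that the two limits leave unreadable from compound 1 to compound 2, and it lies between two limits, so its size is not readable; it also exchanges bromo for pentyl rather than shortening a chain. Going by the values given here, no measured step therefore gives a size or a direction for the change from pentyl to methyl in this assay.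

With that absence, the expectation for compound 4 stays close to compound 3 but wide: compound 4 is estimated at 20000 nM, within 5000 nM to 90000 nM. The expected step is then a 2.0-fold higher number from compound 3 to compound 4 (0.31 log units; beyond the scatter), with a real chance that only a limit is returned.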

Compound 4, half-maximal inhibitory concentration: > 100000 nM
Compound 4 was reported as a limit; the forecaster's own chance of this, stated with the estimate: 30%; at least 5.0-fold (0.69 log units) between middle value and limit.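

For the compounds shown here, replacing 4-pentylphenyl with 4-methylphenyl gives an at least 10-fold higher number from compound 3 to compound 4 (1.00 log units; beyond the scatter) in this assay, the first step at this position with a readable size; one end of it is a limit of the assay, so the true size may be larger. Within this pair, the pentyl chain is therefore not a spare part: with the rest of the molecule unchanged, putting hydrogen in place of butyl on a saturated chain carbon bound to an aromatic carbon is enough to lose the measured number. Compound 3 is now the only compound of the four with a number rather than a limit, so the one measured value shown depends on this chain: the limit of > 100000 nM in this assay, at which 3 of the 4 values shown sit.

On these data alone, it remains open whether an ethyl, propyl or butyl group at this place would keep a number, and whether a longer chain such as heptyl would give a lower number than compound 3 does. Also open, as far as these compounds go, is whether an amine or a carboxylic acid at the end of the chain would be tolerated, and the step between the two limits of the other pair cannot be read.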